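Compound 1 and a carboxy change at the methoxy place

The source may report more compounds than this note shows. Statements on the series, on what has been measured and on what is new or still open speak of the compounds shown alone.

Measured in a functional assay on A549 cells (Homo sapiens) for antiproliferative activity, read by sulforhodamine B assay, with a stated time of 48 h; a lower number here means a stronger inhibitor of growth, a higher number a weaker inhibitor of growth:
compound 1 `COc1ccc(Nc2nc(NC3CCCC3)c3ccccc3n2)cc1` gives 10100 nM
compound 2 `COc1ccc(Nc2nc(NCCCO)c3ccccc3n2)cc1` gives 15200 nM
compound 3 `CNc1nc(Nc2ccc(OC)cc2)nc2ccccc12` gives 16100 nM

The three values lie within the scatter of one another, so compound 1 does not stand apart from the others. The steps (a 1.5-fold higher number from compound 1 to compound 2 (0.18 log units; within the scatter)) and (a 1.6-fold higher number from compound 1 to compound 3 (0.20 log units; within the scatter)) both stay inside the scatter, as does the third (a 1.1-fold higher number from compound 2 to compound 3 (0.02 log units; within the scatter)).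

Compound 4 `O=C(O)c1ccc(Nc2nc(NC3CCCC3)c3ccccc3n2)cc1` keeps the cyclopentyl group of compound 1 and carries carboxy in place of methoxy on an aromatic carbon, para to a large group (carboxy in place of methoxy on an aromatic carbon). All three measured steps change the group on the nitrogen. None touches this place, and the data hold no direct measure for this change. What is expected in this assay is a modest step toward a higher number, held loosely. The estimated step is small (a 1.8-fold higher number from compound 1 to compound 4 (0.25 log units; within the scatter)). For compound 4 the estimated value is 18000 nM with an expected range from 6000 nM to 60000 nM as the upper end.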

Compound 4, concentration for 50% growth inhibition: 28700 nM
For compound 4 the middle estimate is 1.6-fold (0.20 log units) below the measured one; low and high end bracket the measured number.
By their numbers in this assay, from the lowest: compounds 1, 2, 3 and 4 (each within the scatter of the next, the first and the last beyond it).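

In this assay, putting carboxy in place of methoxy gives a 2.8-fold higher number from compound 1 to compound 4 (0.45 log units; beyond the scatter), and this step lies beyond the scatter. The earlier steps all changed the group on the nitrogen and all stayed within the scatter, so this aromatic carbon, para to a large group, is the only place shown where a single change moves the number beyond it. Nothing given here accounts for the size or direction of this step.

Going by these compounds, whether the step is particular to carboxy stays open, since an amine or a primary amide at this place would be needed to tell. Also open, on these data alone, is whether a carboxylic acid on a longer chain here, or carboxy combined with 3-hydroxypropyl or methyl on the nitrogen, would give a similar step.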